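The source may hold more compounds than are shown below. What is called first, only, known or untested is meant among the compounds shown, and "the series" means these compounds.

Working notes on the series

For the measured compounds named here, the shared core carries an anilino group on one side and a thioacetamide arm on the other; the only variation so far is the aryl group on the amide-type nitrogen. Compound 1 `O=C(CSc1nc(Nc2ccccc2)c2ccccc2n1)Nc1ccccc1Br` carries a 2-bromophenyl there and in a functional assay on NCI-H1975 cells (Homo sapiens) for inhibition, read by MTT assay, with a stated time of 72 h (a higher number here means a weaker inhibitor, a lower number a stronger inhibitor), compound 1 gives 10300 nM. Compound 2 `O=C(CSc1nc(Nc2ccccc2)c2ccccc2n1)Nc1cccc(F)c1` carries a 3-fluorophenyl, and in this assay compound 2 gives 6790 nM. Going by the values given here, the one step available, a 1.5-fold lower number from compound 1 to compound 2 (0.18 log units; within the scatter), does not separate the two compounds, so compound 2 stands at the lower of two numbers that are indistinguishable within the scatter.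

Compound 3 `O=C(CSc1nc(Nc2ccccc2)c2ccccc2n1)Nc1ccc(Cl)cc1` is the next member: 4-chlorophenyl in place of 3-fluorophenyl on an amide-type nitrogen. Among the compounds with values here, no measured step moves a halogen between these two positions of the aryl ring, so nothing bears on the change directly; the only step at hand, from 2-bromophenyl to 3-fluorophenyl, was within the scatter, which gives no reason to expect a step beyond it here. The expectation is that compound 3 gives 6000 nM in this assay, within 2500 nM to 15000 nM. The step this implies, a 1.1-fold lower number from compound 2 to compound 3 (0.05 log units; within the scatter), is expected to stay within the scatter.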

Compound 3, half-maximal inhibitory concentration: 8040 nM
Beside the measured number, compound 3's estimate is 1.3-fold (0.13 log units) below it; the measured number falls inside the stated range.
By their numbers in this assay, from the lowest: compounds 2, 3 and 1 (each within the scatter of the next).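

Replacing 3-fluorophenyl with 4-chlorophenyl on the amide-type nitrogen does not give a readable change in this assay (a 1.2-fold higher number from compound 2 to compound 3 (0.07 log units; within the scatter)), and neither does replacing 2-bromophenyl with 4-chlorophenyl (a 1.3-fold lower number from compound 1 to compound 3 (0.11 log units; within the scatter)). With the earlier step, this makes three halogen-bearing phenyl groups whose numbers all lie within the scatter of one another, so the series so far shows no separation among these three groups at this position. Each of these changes alters both the halogen and its place on the ring, and no evidence bears on the result.

The compounds shown leave open whether the halogen or its ring position matters on its own, which a pair such as 3-chlorophenyl and 4-chlorophenyl would address directly. They also leave open whether a group of another kind on the amide-type nitrogen, such as a phenyl ring carrying a carboxylic acid or an amine, or a benzyl group with a longer chain to the ring, would give a step beyond the scatter.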